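A few compounds are considered here, and "the series" means these few. Any claim that something is new, unique, unknown or untested is made for them only; others in the source may bear on it.

Of the compounds shown here, three with a shared core have been measured in a functional assay on OVCAR-3 cells (Homo sapiens) for antiproliferative activity, read by MTT assay, with a stated time of 24 h; on this read-out lower numbers stand for stronger inhibition and higher numbers for weaker inhibition. Compound 1 `O=c1[nH]cc(S(=O)(=O)Nc2ccc(-c3cn(-c4ccccc4)nn3)cc2)c(=O)[nH]1` gives 18000 nM. Compound 2 `Cc1cccc(-n2cc(-c3ccc(NS(=O)(=O)c4c[nH]c(=O)[nH]c4=O)cc3)nn2)c1`, with methyl in place of hydrogen on an aromatic carbon, gives 7490 nM, so that a 2.4-fold lower number from compound 1 to compound 2 (0.38 log units; beyond the scatter). Compound 3 `O=c1[nH]cc(S(=O)(=O)Nc2ccc(-c3cn(-c4ccc(F)cc4)nn3)cc2)c(=O)[nH]1`, with fluoro in place of hydrogen on an aromatic carbon, reaches only a limit of the assay, > 20000 nM, a case of the limit of > 20000 nM in this assay, at which 1 of the 3 values shown sits, so compound 3 stands as the weakest of the three shown. The steps of an at least 1.1-fold higher number from compound 1 to compound 3 (0.04 log units; that floor lies within the scatter) and an at least 2.6-fold higher number from compound 2 to compound 3 (0.42 log units; beyond the scatter) describe how it was reached.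

Compound 4 `O=c1[nH]cc(S(=O)(=O)Nc2ccc(-c3cn(-c4ccc(Cl)cc4)nn3)cc2)c(=O)[nH]1` differs from compound 3 by chloro in place of fluoro on an aromatic carbon. Among the compounds with values here, no measured step exchanges one halogen for another, so the steps to compound 3 bear only indirectly on it: they show that a small group on this ring can leave the number near or at the limit. No step beyond the scatter is therefore expected, and compound 4 is estimated to show a step that the limit leaves unreadable from compound 3 to compound 4. Compound 4 is expected to give about 22000 nM, within 9000 nM to 60000 nM, likely again only as a limit.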

Compound 4, half-maximal inhibitory concentration: 2160 nM
Compound 4: the middle estimate sits 10-fold (1.01 log units) above what was measured; measured number outside the range, below it.
By their numbers in this assay, from the lowest: compound 4; then compound 2; then compound 1. At a limit, above all of these: compound 3.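

In this assay, within the data shown here, the group on this aromatic carbon, para to a large group, matters far more than the earlier compounds suggested: chloro in place of fluoro gives a large change (an at least 9.2-fold lower number from compound 3 to compound 4 (0.96 log units; beyond the scatter)), so two halogens at one place are not interchangeable here. Chloro also improves on hydrogen (an 8.3-fold lower number from compound 1 to compound 4 (0.92 log units; beyond the scatter)) and on the 3-methylphenyl of compound 2 (a 3.5-fold lower number from compound 2 to compound 4 (0.54 log units; beyond the scatter)), which makes compound 4 the strongest of the four shown. Compound 3 stands only at a limit of the assay, so its step gives a floor and not a full size: (the limit of > 20000 nM in this assay, at which 1 of the 4 values shown sits).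

On these data alone, whether bromo, methoxy or an amine at this place would behave like chloro or like fluoro stays open. Compound 2 and compound 4 differ in both the group and where it sits on the ring, so the compounds shown cannot separate those two changes.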